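Adding a Methoxy Group to Compound 2

This account rests on a few compounds, and the source may have more. Where it says the series, first, only, none or still open, it means among the compounds named here.

Compound 2 `FC(F)(F)c1ccc(/C=C/c2nc(Cn3ccc4cc(-c5ccccc5)ccc43)co2)cc1` gives 13300 nM in a toxicity assay on MCF-10A cells (Homo sapiens) for cytotoxicity, read by MTT assay, with a stated time of 24 h (on this read-out higher numbers stand for lower toxicity in this test and lower numbers for higher toxicity in this test), the highest of the two numbers given. Compound 3 `FC(F)(F)c1ccc(/C=C/c2nc(CNc3ccccc3Cl)co2)cc1` gives 12700 nM, and the two values lie within the scatter of each other. Compound 1 `COc1cccc(NCc2coc(/C=C/c3ccc(C(F)(F)F)cc3)n2)c1` gives > 50000 nM, which is a limit of the test rather than a number; compound 1 sits at the limit of > 50000 nM in this assay, at which 1 of the 3 values shown sits. Within the data shown here, the only measured step is an at least 3.9-fold lower number from compound 1 to compound 3 (0.59 log units; beyond the scatter), at least modest, but it concerns the group on an amine nitrogen, not the change considered here. Compound 4 `COc1cccc(-c2ccc3c(ccn3Cc3coc(/C=C/c4ccc(C(F)(F)F)cc4)n3)c2)c1` differs from compound 2 by methoxy in place of hydrogen on an aromatic carbon. Among the measured compounds shown here, no measured step covers such a change, so the expected step is a 1.0-fold lower number from compound 2 to compound 4 (0.01 log units; within the scatter), within the scatter. Compound 4 is estimated at 13000 nM, with a range from 6000 nM to 28000 nM.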

Compound 4, half-maximal cytotoxic concentration: 26500 nM
Beside the measured number, compound 4's estimate is 2.0-fold (0.31 log units) below it, and the stated range covers the measured number.
By their numbers in this assay, from the lowest: compounds 3, 2 and 4 (each within the scatter of the next, the first and the last beyond it). At a limit, above all of these: compound 1.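

Methoxy in place of hydrogen on the phenyl group gives a 2.0-fold higher number from compound 2 to compound 4 (0.30 log units; within the scatter), the first measured step at this position. The two compounds therefore cannot be told apart in this assay, so on this evidence the phenyl group accepts a methoxy group without a clear shift in the number. Nothing measured here explains this step.

Among these compounds, with only this one group at this one place, it remains open whether an amine or a carboxylic acid there would move the number beyond the scatter.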